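This account rests on a few compounds, and the source may have more. Where it says the series, first, only, none or still open, it means among the compounds named here.

Measured in a functional assay on A-375 cells (Homo sapiens) for cytotoxicity, read by MTT assay, with a stated time of 72 h, tested at 10 uM; a higher number here means more inhibition of growth at the concentration tested, a lower number less inhibition of growth:

compound 1, `N/C(=N\NC(=S)N1CCCCCC1)c1ccccn1`, 86.5%
compound 2, `N/C(=N\NC(=S)N1CCOCC1)c1ccccn1`, 18.3%
compound 3, `N/C(=N\NC(=S)N1CCOCC1)c1ccc(F)cn1`, 70.3%

Compound 1 gives the highest number of the three; compound 2 gives the lowest, and compound 3 sits between them. The difference between the cores of compound 1 and compound 2 is not broken down here. Going from compound 2 to compound 3 is fluoro in place of hydrogen on an aromatic carbon, and this step is a number 52 percentage points higher from compound 2 to compound 3 (beyond the scatter).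

Compound 4, `N/C(=N\NC(=S)N1CCCCCC1)c1ccc(F)cn1`, is not yet measured in this assay. It is reached from compound 1 by fluoro in place of hydrogen on an aromatic carbon, the same kind of change as from compound 2 to compound 3. Because compound 1 already stands at 86.5%, a gain as large as the earlier one is not expected; the expected step is a number 3.5 percentage points higher from compound 1 to compound 4 (within the scatter). Compound 4 is estimated at 90%, with a range from 76% to 98%.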

Compound 4, percent growth inhibition at one concentration: 72.2%
Estimate against measurement, compound 4: 17.8 percentage points above; measured number below the stated range.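

In this assay fluoro in place of hydrogen on an aromatic carbon is a number 14.3 percentage points lower from compound 1 to compound 4 (beyond the scatter) and does not repeat the step seen on the core of compound 2. The effect of this change on growth inhibition therefore cannot be carried from one core to the other in this series, but these two pairs do not show why the cores differ, and they set no rule for any further core. The two steps differ in direction and size: the same change on two cores in this assay, a number 52 percentage points higher (beyond the scatter) from compound 2 to compound 3 and a number 14.3 percentage points lower (beyond the scatter) from compound 1 to compound 4, 66.3 percentage points apart, beyond the scatter of two such steps

Open, from the compounds shown here alone, is whether chloro or methyl at the same place would follow the fluoro step on each core. Also open, going by these compounds, is how an amine or a carboxylic acid there would behave.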